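The source may hold more compounds than are shown below. What is called first, only, known or untested is meant among the compounds shown, and "the series" means these compounds.

In a functional assay on HCT-116 cells (Homo sapiens) for antiproliferative activity, read by MTT assay, with a stated time of 72 h (a lower number here means a stronger inhibitor, a higher number a weaker inhibitor), three compounds with the same core and different aryl groups on the ring amine nitrogen have been measured. Compound 1 `Nc1nc(N)c2cc(CSC(=S)N3CCN(c4ccc(Cl)c(Cl)c4)CC3)ccc2n1` gives 6680 nM as its value, compound 2 `Nc1nc(N)c2cc(CSC(=S)N3CCN(c4ccc(F)cc4)CC3)ccc2n1` gives 3270 nM and compound 3 `Nc1nc(N)c2cc(CSC(=S)N3CCN(c4ccccc4[N+](=O)[O-])CC3)ccc2n1` gives 5520 nM in the same test. Compound 3 stands within the scatter of both others, with a 1.2-fold lower number from compound 1 to compound 3 (0.08 log units; within the scatter) and a 1.7-fold higher number from compound 2 to compound 3 (0.23 log units; within the scatter) as its two steps.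

Compound 4 `Nc1nc(N)c2cc(CSC(=S)N3CCN(c4ncccn4)CC3)ccc2n1` carries pyrimidin-2-yl in place of 2-nitrophenyl on an amine nitrogen in a ring. All three measured steps change this same place. For the measured compounds named here, the largest of them, a 2.0-fold lower number from compound 1 to compound 2 (0.31 log units; beyond the scatter), is only modest, and none of the measured compounds carries a ring with hetero atoms there, so that reading across is uncertain. Any step in this assay is therefore expected to be small, with none beyond the scatter. The expected step is a 1.2-fold lower number from compound 3 to compound 4 (0.09 log units; within the scatter) by this estimate. For compound 4 the estimated value is 4500 nM, expected to fall from 2000 nM to 10000 nM when tested.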

Compound 4, half-maximal inhibitory concentration: 5840 nM
Estimate against measurement, compound 4: 1.3-fold (0.11 log units) below, within the range that was stated.
By their numbers in this assay, from the lowest: compounds 2, 3, 4 and 1 (each within the scatter of the next, the first and the last beyond it).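

In this assay, for the compounds shown here, pyrimidin-2-yl is the first ring with hetero atoms on this amine nitrogen, and compound 4 stays within the scatter of all three compounds with a carbon-only aromatic ring, with a 1.1-fold higher number from compound 3 to compound 4 (0.02 log units; within the scatter) and a 1.8-fold higher number from compound 2 to compound 4 (0.25 log units; within the scatter) and a 1.1-fold lower number from compound 1 to compound 4 (0.06 log units; within the scatter) as its steps. Among these four compounds, then, neither the hetero atoms in the ring nor the change from 9 to 6 heavy atoms against 2-nitrophenyl gives a step beyond the scatter at this position. No evidence is at hand on why these numbers stay so close.

The compounds shown leave open whether a group without an aromatic ring at this nitrogen, such as a simple ethyl chain or an acetyl group, would keep the number in this range. They also leave open whether a carboxylic acid or an amine on the aromatic ring would shift it.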